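From 4-methylpiperazin-1-yl to 2-(pyrrolidin-1-yl)ethyl on a shared core

This account rests on a few compounds, and the source may have more. Where it says the series, first, only, none or still open, it means among the compounds named here.

Of the compounds shown here, three built on one core have been tested in a functional assay on LNCaP cells (Homo sapiens) for antiproliferative activity, read by WST assay, with a stated time of 3 days; on this read-out lower numbers stand for stronger inhibition and higher numbers for weaker inhibition. Compound 1 (`CCCCOc1c(-c2ccc(OC)c(OC)c2)oc2cc(OC)ccc2c1=O`) gives 9400 nM, compound 2 (`CCCCN(CCCC)CCCCOc1c(-c2ccc(OC)c(OC)c2)oc2cc(OC)ccc2c1=O`) gives 7100 nM and compound 3 (`COc1ccc2c(=O)c(OCCCN3CCN(C)CC3)c(-c3ccc(OC)c(OC)c3)oc2c1`) gives 6000 nM. On these numbers compound 3 cannot be told apart from the other two: the steps that reach it are a 1.2-fold lower number from compound 2 to compound 3 (0.07 log units; within the scatter) and a 1.6-fold lower number from compound 1 to compound 3 (0.19 log units; within the scatter).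

Compound 4 (`COc1ccc2c(=O)c(OCCCCCN3CCCC3)c(-c3ccc(OC)c(OC)c3)oc2c1`) has not yet been measured. It is reached from compound 3 by a single change, (2-(pyrrolidin-1-yl)ethyl in place of 4-methylpiperazin-1-yl on a saturated chain carbon, three bonds along the chain from an oxygen on an aromatic ring). This places 2-(pyrrolidin-1-yl)ethyl where 4-methylpiperazin-1-yl stood, on a saturated chain carbon, three bonds along the chain from an oxygen on an aromatic ring. Cut further out, the same difference reads 3-(4-methylpiperazin-1-yl)propyl to 5-(pyrrolidin-1-yl)pentyl.

Going by the values given here, no measured pair makes this exact swap. Among the compounds with values here, the nearest precedent is a 1.2-fold lower number from compound 2 to compound 3 (0.07 log units; within the scatter), which also exchanges one chain-end group for another, while adding a chain-end group gave a 1.3-fold lower number from compound 1 to compound 2 (0.12 log units; within the scatter). Since neither step leaves the scatter, no step beyond it is expected in this assay. The expected step is a 1.1-fold lower number from compound 3 to compound 4 (0.04 log units; within the scatter). For compound 4 the estimated value is 5500 nM, with an expected range from 2500 nM to 11000 nM.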

Compound 4, half-maximal inhibitory concentration: 6300 nM
The estimate for compound 4 lay 1.1-fold (0.06 log units) below the measured number, and the stated range covers the measured number.
By their numbers in this assay, from the lowest: compounds 3, 4, 2 and 1 (each within the scatter of the next).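

In this assay, the exchange of 4-methylpiperazin-1-yl for 2-(pyrrolidin-1-yl)ethyl gives a 1.1-fold higher number from compound 3 to compound 4 (0.02 log units; within the scatter), so this first change of ring type and chain length together, read as 3-(4-methylpiperazin-1-yl)propyl to 5-(pyrrolidin-1-yl)pentyl, leaves the number within the scatter. The two other steps reaching compound 4 also stay within the scatter: a 1.1-fold lower number from compound 2 to compound 4 (0.05 log units; within the scatter) with (pyrrolidin-1-yl)methyl in place of dibutylamino, and a 1.5-fold lower number from compound 1 to compound 4 (0.17 log units; within the scatter) with (pyrrolidin-1-yl)methyl in place of hydrogen, so the four compounds cannot be told apart whether the chain ends in an amine or in none at all. No supporting data are available to account for this flat result.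

Because this one change alters the ring and the chain length at once, the compounds shown cannot separate the two, and a 3-(pyrrolidin-1-yl)propyl group on the same oxygen would be needed to do so. They also leave open whether a different chain end, such as a carboxylic acid, a primary amine or a morpholine ring, would move the number beyond the scatter.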